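Swapping Propargyl for a Piperidine on the Oxygen

The source may hold more compounds than are shown below. What is called first, only, known or untested is meant among the compounds shown, and "the series" means these compounds.

Compound 1 `C#CCOc1ccc(C(=O)Nc2cc3ccc(OC4CCN(C)CC4)c(C)c3oc2=O)cc1CC=C(C)C` gives 1400 nM
Compound 2 `Cc1c(OC2CCN(C)CC2)ccc2cc(NC(=O)c3ccc(O)cc3)c(=O)oc12` gives 840 nM

In a functional assay on SK-BR-3 cells (Homo sapiens) for antiproliferative activity (on this read-out lower numbers stand for stronger inhibition and higher numbers for weaker inhibition), compound 1 at 1400 nM lies within the usual scatter of compound 2, so neither stands apart. The change 1-methylpiperidin-4-yl in place of propargyl on an oxygen on an aromatic ring puts 1-methylpiperidin-4-yl in place of propargyl on an oxygen on an aromatic ring of compound 1, giving compound 3 `CC(C)=CCc1cc(C(=O)Nc2cc3ccc(OC4CCN(C)CC4)c(C)c3oc2=O)ccc1OC1CCN(C)CC1` with the rest unchanged. Among the measured compounds shown here, no measured pair shows this swap, so the direction cannot be read from the data. The expected move is a 1.4-fold lower number from compound 1 to compound 3 (0.15 log units; within the scatter) and no step beyond the scatter. For compound 3 the estimated value is 1000 nM with a range from 300 nM to 3500 nM in this estimate.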

Compound 3, half-maximal inhibitory concentration: 210 nM
The estimate for compound 3 lay 4.8-fold (0.68 log units) above the measured number; measured number below the stated range.
By their numbers in this assay, from the lowest: compound 3; then compounds 2 and 1 (each within the scatter of the next).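

In this assay, 1-methylpiperidin-4-yl in place of propargyl on an oxygen on an aromatic ring brings a 6.7-fold lower number from compound 1 to compound 3 (0.82 log units; beyond the scatter) and this step lies beyond the usual scatter. So the group on this oxygen can clearly shift antiproliferative activity, and the larger, nitrogen-bearing ring is the better of the two groups tried here. Nothing available explains why the number falls. Whether the nitrogen or the ring itself matters stays open, since the compounds shown include neither cyclohexyl nor morpholine on this oxygen. An open-chain amine such as 2-(dimethylamino)ethyl is also absent.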